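The source may report more compounds than this note shows. Statements on the series, on what has been measured and on what is new or still open speak of the compounds shown alone.

Of the compounds shown here, three built on one shared core have been measured in an assay on FRT cells for positive allosteric modulation of Cystic fibrosis transmembrane conductance regulator variant N1303K (Homo sapiens), in the presence of a further agent that is not named here; a lower number here means that less compound is needed, a higher number that more compound is needed for the effect. Compound 1 `COc1ccc2[nH]c3c(c2c1)CCNC31CCN(Cc2ccccc2)CC1` carries a plain phenyl on the saturated chain carbon bound to the ring amine nitrogen and gives 12600 nM. Compound 2 `COc1ccc2[nH]c3c(c2c1)CCNC31CCN(Cc2ccc([N+](=O)[O-])cc2F)CC1` carries a 2-fluoro-4-nitrophenyl at that place and gives 5900 nM. Compound 3 `COc1ccc2[nH]c3c(c2c1)CCNC31CCN(Cc2cc(F)cc(F)c2)CC1` carries a 3,5-difluorophenyl there and gives 11100 nM. Among the three values compound 3 stands second highest: a 1.1-fold lower number from compound 1 to compound 3 (0.06 log units; within the scatter) lies within the scatter, and so does a 1.9-fold higher number from compound 2 to compound 3 (0.27 log units; within the scatter). Only a 2.1-fold lower number from compound 1 to compound 2 (0.33 log units; beyond the scatter) goes beyond the scatter, and that step is modest.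

Compound 4 `COc1ccc2[nH]c3c(c2c1)CCNC31CCN(Cc2cc(F)c(F)c(F)c2)CC1` has not yet been measured. It differs from compound 3 by fluoro in place of hydrogen on an aromatic carbon.

Among the compounds with values here, the steps that bear on this change are those in which the substituents on this same phenyl ring were varied. Two of the three were within the scatter, and the one that went beyond it was modest. A single added fluoro is a smaller change than any of those, so no step beyond the scatter is expected in this assay, in either direction.

Compound 4 is therefore expected to give 9500 nM, with a range from 4000 nM to 22000 nM. The step this estimate implies is a 1.2-fold lower number from compound 3 to compound 4 (0.07 log units; within the scatter), and it is expected to remain within the scatter.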

Compound 4, half-maximal effective concentration: 2600 nM
For compound 4 the middle estimate is 3.7-fold (0.56 log units) above the measured one; measured number outside the range, below it.
By their numbers in this assay, from the lowest: compound 4; then compounds 2, 3 and 1 (each within the scatter of the next, the first and the last beyond it).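

In this assay, one fluoro on the aromatic carbon ortho to two fluoro groups and para to a large group makes a clear difference, a 4.3-fold lower number from compound 3 to compound 4 (0.63 log units; beyond the scatter), whereas the earlier change from phenyl to 3,5-difluorophenyl stayed within the scatter, a 1.1-fold lower number from compound 1 to compound 3 (0.06 log units; within the scatter). The 3,4,5-trifluorophenyl group also gives a lower number than both the 2-fluoro-4-nitrophenyl group, a 2.3-fold lower number from compound 2 to compound 4 (0.36 log units; beyond the scatter), and plain phenyl, a 4.8-fold lower number from compound 1 to compound 4 (0.69 log units; beyond the scatter), so compound 4 now has the lowest number of the four and is the only one beyond the scatter of all the others. Nothing given here explains why this single atom has such an effect. From the compounds shown here alone, it remains open whether a fluoro on this carbon would lower the number without the two fluoro groups on either side of it, as a 4-fluorophenyl group would test. Going by these compounds, it is also open whether this carbon needs fluoro in particular, or whether a chloro, a methoxy or an amine in the same place, with the 3,5-difluoro pattern kept, would do the same.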